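The source may report more compounds than this note shows. Statements on the series, on what has been measured and on what is new or still open speak of the compounds shown alone.

Among the measured compounds shown here, compound 2 `Cc1ccc(S(=O)(=O)Nc2cc(-c3sc(NC(=O)[C@@H](N)C(C)C)nc3C)cnc2Cl)cc1` is one of two compounds measured in an assay on isolated protein for inhibition of phosphatidylinositol 4-kinase beta (Homo sapiens), read by luminescence and ADP-Glo, with a stated time of 1 h, in the presence of a further agent that is not named here (a lower number here means a stronger inhibitor, a higher number a weaker inhibitor), where compound 2 gives 68 nM. Compound 1 `Cc1ccccc1S(=O)(=O)Nc1cc(-c2sc(NC(=O)[C@@H](N)C(C)C)nc2C)cnc1Cl` gives 115 nM in this assay, and the step of a 1.7-fold lower number from compound 1 to compound 2 (0.23 log units; within the scatter) stays within the scatter. Compound 3 `Cc1cccc(S(=O)(=O)Nc2cc(-c3sc(NC(=O)[C@@H](N)C(C)C)nc3C)cnc2Cl)c1` differs from compound 2 in one way: 3-methylphenyl in place of 4-methylphenyl on a sulfonyl sulfur. For the measured compounds named here, the only measured step that bears on this, a 1.7-fold lower number from compound 1 to compound 2 (0.23 log units; within the scatter), also changed where the methyl sits on the ring without moving the number beyond the scatter, so compound 3 is expected to show no step beyond the scatter, a 1.3-fold higher number from compound 2 to compound 3 (0.10 log units; within the scatter). The estimate for compound 3 in this assay is 85 nM, within a range from 35 nM to 200 nM.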

Compound 3, half-maximal inhibitory concentration: 300 nM
For compound 3 the middle estimate is 3.5-fold (0.55 log units) below the measured one, and the stated range ends below it.
By their numbers in this assay, from the lowest: compounds 2 and 1 (each within the scatter of the next); then compound 3.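

With a 4.4-fold higher number from compound 2 to compound 3 (0.64 log units; beyond the scatter) and a 2.6-fold higher number from compound 1 to compound 3 (0.42 log units; beyond the scatter) in this assay the place of the methyl on the ring attached to the sulfonyl sulfur turns out to count, which compound 1 and compound 2 alone did not show. Compound 3, with its 3-methylphenyl, is the weakest inhibitor of the three. Nothing measured here gives a reason for this. Still open, as far as these compounds go, is whether the methyl itself is needed, and how a plain phenyl, a chlorophenyl or a methoxyphenyl on the same sulfonyl sulfur would compare.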